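Shrinking the Group on the Aromatic Nitrogen

This account rests on a few compounds, and the source may have more. Where it says the series, first, only, none or still open, it means among the compounds named here.

Compound 1 `Cc1cc(NC(=O)Cn2nnc(-c3ccccc3)n2)n(C2CCCCC2)n1` carries a cyclohexyl on an aromatic nitrogen of its core. In an assay on HEK293 cells for activation of Kir3.1/Kir3.2 (Homo sapiens), read by thallium flux (on this read-out lower numbers stand for smaller maximal responses and higher numbers for larger maximal responses), compound 1 gives 92%, the lower of the two numbers recorded, with compound 2 nearest. Compound 2 `Cc1cc(NC(=O)Cn2nnc(-c3ccccc3)n2)n(C2CCOCC2)n1` gives 115%, a change of a number 23 percentage points higher from compound 1 to compound 2 (beyond the scatter). Compound 3 `Cc1cc(NC(=O)Cn2nnc(-c3ccccc3)n2)n(C2CCC(C)(C)CC2)n1` reached only a limit of this assay, > 19%. That reading sits at the limit of > 19% in this assay, at which 1 of the 3 values shown sits, so the size of its step from compound 1 stays unreadable. Compound 4 `Cc1cc(NC(=O)Cn2nnc(-c3ccccc3)n2)n(C(C)C)n1` differs from compound 1 thus: isopropyl in place of cyclohexyl on an aromatic nitrogen. Within the data shown here, no measured step trades the ring for a shorter chain, so no step beyond the scatter is expected, a number 2 percentage points lower from compound 1 to compound 4 (within the scatter). Compound 4 is therefore estimated at 90%, between 60% and 115%.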

Compound 4, largest response reached (Emax), in percent of the reference or control that the assay uses: 107%
Beside the measured number, compound 4's estimate is 17 percentage points below it; measured number inside the range.
By their numbers in this assay, from the lowest: compound 1; then compounds 4 and 2 (each within the scatter of the next).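

A ring on this nitrogen is not needed for a large response in this assay: isopropyl in place of cyclohexyl gives a number 15 percentage points higher from compound 1 to compound 4 (beyond the scatter). Set against the oxan-4-yl group, the open chain gives a number 8 percentage points lower from compound 2 to compound 4 (within the scatter), so compound 2 and compound 4 cannot be told apart here. Compound 3 stands only at a limit, so its steps cannot be read: the limit of > 19% in this assay, at which 1 of the 4 values shown sits.

As far as these compounds go, how methyl, or a longer chain such as butyl, would read on this nitrogen stays open. So does whether an amine on the ring would behave like the oxan-4-yl group.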